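Dimethylphenyl isomers in the cytotoxicity series

The compounds below may be only part of what the source reports. "The series", "measured", "known", "first", "only" and "open" are said of these compounds alone.

Values in a functional assay on C8166 cells (Homo sapiens) for cytotoxicity, read by MTT assay; on this read-out higher numbers stand for lower toxicity in this test and lower numbers for higher toxicity in this test:
- compound 1 `Cc1cc(S(N)(=O)=O)ccc1NC(=O)COc1ccc(Cl)cc1NC(=O)c1ccccc1C`: 67300 nM
- compound 2 `Cc1cc(S(N)(=O)=O)ccc1NC(=O)COc1ccc(Cl)cc1NC(=O)c1cccc(F)c1`: 243000 nM
- compound 3 `Cc1ccc(C)c(C(=O)Nc2cc(Cl)ccc2OCC(=O)Nc2ccc(S(N)(=O)=O)cc2C)c1`: 79700 nM

In this assay compound 3 gives 79700 nM, within the scatter of compound 1. The wider gap is a 3.0-fold lower number from compound 2 to compound 3 (0.48 log units; beyond the scatter). Compound 4 `Cc1ccc(C(=O)Nc2cc(Cl)ccc2OCC(=O)Nc2ccc(S(N)(=O)=O)cc2C)cc1C` carries 3,4-dimethylphenyl in place of 2,5-dimethylphenyl on a carbonyl carbon. The nearest measured change is a 1.2-fold higher number from compound 1 to compound 3 (0.07 log units; within the scatter). Larger steps appear only with the 3-fluorophenyl compound: a 3.6-fold higher number from compound 1 to compound 2 (0.56 log units; beyond the scatter) and the gap already given. For the measured compounds named here, no measured compound carries 3,4-dimethylphenyl, so no step beyond the scatter is expected, and the expected step is a 1.2-fold higher number from compound 3 to compound 4 (0.08 log units; within the scatter). The estimate for compound 4 is 95000 nM, with an expected range of 50000 nM to 200000 nM.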

Compound 4, half-maximal cytotoxic concentration: 84100 nM
Estimate against measurement, compound 4: 1.1-fold (0.05 log units) above; measured number inside the range.
By their numbers in this assay, from the lowest: compounds 1, 3 and 4 (each within the scatter of the next); then compound 2.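

In this assay, 3,4-dimethylphenyl in place of 2,5-dimethylphenyl on a carbonyl carbon gives a 1.1-fold higher number from compound 3 to compound 4 (0.02 log units; within the scatter), so these two placements of the methyl groups do not separate here. Compound 4 also stays close to the 2-methylphenyl compound, with a 1.2-fold higher number from compound 1 to compound 4 (0.10 log units; within the scatter), while the 3-fluorophenyl compound remains apart, with a 2.9-fold lower number from compound 2 to compound 4 (0.46 log units; beyond the scatter). No evidence on the origin of these differences is available.

Open, going by these compounds, is whether the gap to compound 2 follows the fluorine or the absence of a methyl group. A 3-methylphenyl or 3-chlorophenyl group at this carbonyl carbon would address that.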